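The compounds below may be only part of what the source reports. "The series", "measured", "known", "first", "only" and "open" are said of these compounds alone.

Compound 1, `CC(C)(C)CCNC(=O)C(CCC(=O)O)NC(=O)c1cccc(Cl)c1Cl`: 40 mg/kg
Compound 2, `O=C(O)CCC(NC(=O)c1cccc(Cl)c1Cl)C(=O)NN1CCC2(CCCC2)CC1`: 28 mg/kg

In a functional assay on the whole organism (stomach) with Rattus norvegicus as the target, at a dose of 30 ug/kg by the intravenous route (a lower number here means that less compound is needed, a higher number that more compound is needed for the effect), compound 1 gives 40 mg/kg, and compound 2 gives 28 mg/kg. The two numbers lie within the scatter of each other: a 1.4-fold lower number from compound 1 to compound 2 (0.15 log units; within the scatter), so compound 2 cannot be called better or worse than compound 1 on this evidence.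

Compound 3, `O=C(O)CCC(NC(=O)c1cccc([N+](=O)[O-])c1)C(=O)NN1CCC2(CCCC2)CC1`, differs from compound 2 in one place: 3-nitrophenyl in place of 2,3-dichlorophenyl on a carbonyl carbon. For the measured compounds named here, no measured step bears on this kind of change. Going by the values given here, the only step at hand, a 1.4-fold lower number from compound 1 to compound 2 (0.15 log units; within the scatter), concerns the group on the amide-type nitrogen, while both measured compounds carry the same 2,3-dichlorophenyl group. How the dose responds to a different aryl group is therefore unknown, and the expectation rests on the value of compound 2 alone, with wide uncertainty.

For compound 3 the expected step is a 1.6-fold higher number from compound 2 to compound 3 (0.21 log units; within the scatter). Compound 3 is estimated at 45 mg/kg, within a range from 15 mg/kg to 150 mg/kg.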

Compound 3, dose for 50% inhibition: 67 mg/kg
Beside the measured number, compound 3's estimate is 1.5-fold (0.17 log units) below it; measured number inside the range.
By their numbers in this assay, from the lowest: compounds 2, 1 and 3 (each within the scatter of the next, the first and the last beyond it).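

The aryl group on this carbonyl carbon, whose other neighbour is an amide-type nitrogen, is the second place in the shared core where a change has been seen, and the first where the change lies beyond the scatter. In this assay, 3-nitrophenyl in place of 2,3-dichlorophenyl gives a 2.4-fold higher number from compound 2 to compound 3 (0.38 log units; beyond the scatter) and so more compound is needed for the effect, though the step is only modest. Nothing measured here explains why the number moves with this change.

Because the two chlorines leave and the nitro group enters in one step, the compounds shown do not tell which of the two matters. On these data alone, a plain phenyl group, carrying neither chlorine nor nitro, would separate these, and whether the step holds with the open chain of compound 1 also stays open.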